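Sulfonyl substituent changes in a prostaglandin receptor antagonist series

This account rests on a few compounds, and the source may have more. Where it says the series, first, only, none or still open, it means among the compounds named here.

Measured in a functional assay on CHO.K1 cells for antagonist activity at prostaglandin D2 receptor 2 (Homo sapiens), read by GTPgammaS binding, with a stated time of 1 h; on this read-out higher numbers stand for weaker inhibition and lower numbers for stronger inhibition:
compound 1 `Cc1c(Cc2ccccc2S(=O)(=O)c2ccccc2F)c2c(n1CC(=O)O)CCNC2=O` gives 3.6 nM
compound 2 `Cc1c(Cc2ccccc2S(=O)(=O)c2ccc(F)cc2)c2c(n1CC(=O)O)CCNC2=O` gives 3.3 nM
compound 3 `COc1ccc(S(=O)(=O)c2ccccc2Cc2c3c(n(CC(=O)O)c2C)CCNC3=O)cc1` gives 3.9 nM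

Compound 3 has the highest of the three numbers, but the steps of a 1.1-fold higher number from compound 1 to compound 3 (0.03 log units; within the scatter) and a 1.2-fold higher number from compound 2 to compound 3 (0.07 log units; within the scatter) both lie within the scatter, as does a 1.1-fold lower number from compound 1 to compound 2 (0.04 log units; within the scatter). No order among the three compounds can be read from these values.

Compound 4 `Cc1c(Cc2ccccc2S(=O)(=O)N(C)Cc2ccccc2)c2c(n1CC(=O)O)CCNC2=O` differs from compound 3 by benzyl(methyl)amino in place of 4-methoxyphenyl on a sulfonyl sulfur. Every measured step exchanges one aryl group for another, or one substituent on that aryl for another, at the same sulfonyl sulfur, and none of them moved the number beyond the scatter. For the measured compounds named here, that tells the sulfonyl aryl tolerates such exchanges, but no measured step replaces the aryl itself with benzyl(methyl)amino, so the bearing of the earlier steps on this change is indirect only. In this assay compound 4 is expected to give 10 nM with a range of 2 nM to 60 nM. The expected step of a 2.6-fold higher number from compound 3 to compound 4 (0.41 log units; beyond the scatter) is thus a small rise, carrying wide uncertainty.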

Compound 4, half-maximal inhibitory concentration: 26 nM
Compound 4: the middle estimate sits 2.6-fold (0.41 log units) below what was measured, within the range that was stated.
By their numbers in this assay, from the lowest: compounds 2, 1 and 3 (each within the scatter of the next); then compound 4.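

In this assay, for the compounds shown here, this sulfonyl sulfur gives the first change that moves the number beyond the scatter: benzyl(methyl)amino in place of an aryl group gives a 6.7-fold higher number from compound 3 to compound 4 (0.82 log units; beyond the scatter), a 7.9-fold higher number from compound 2 to compound 4 (0.90 log units; beyond the scatter) and a 7.2-fold higher number from compound 1 to compound 4 (0.86 log units; beyond the scatter). The tolerance seen among 2-fluorophenyl, 4-fluorophenyl and 4-methoxyphenyl therefore does not extend to this group, even though it also carries one six-membered aromatic ring of carbon only. No supporting data bear on the cause of this rise.

The compounds shown leave open whether the rise follows from the amino nitrogen on the sulfur, its methyl or its benzyl part. Methyl(phenyl)amino, dimethylamino or morpholine on the same sulfonyl sulfur would help to separate these parts.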